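This account rests on a few compounds, and the source may have more. Where it says the series, first, only, none or still open, it means among the compounds named here.

Measured so far:
compound 1, `O=c1nc(NCc2cccc(F)c2)oc2c([N+](=O)[O-])cc(C(F)(F)F)cc12`, in an ADME assay on Vero cells (Chlorocebus sabaeus) for cytotoxicity, read by MTT assay, with a stated time of 48 h; on this read-out lower numbers stand for stronger inhibition and higher numbers for weaker inhibition: > 64 ug/mL.
compound 2, `O=c1nc(NC2CCCCC2)oc2c([N+](=O)[O-])cc(C(F)(F)F)cc12`, in this assay: 5.39 ug/mL.

For compound 1 the value in this assay is a limit of the assay and not a number (the limit of > 64 ug/mL in this assay, at which 1 of the 2 values shown sits). Compound 2 thus gives the only number shown in this assay, the other entry being a limit. For the measured compounds named here, the single step between measured compounds, an at least 11-fold lower number from compound 1 to compound 2 (1.07 log units; beyond the scatter), is large and beyond the scatter.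

Compound 3, `O=c1nc(Nc2ccccc2)oc2c([N+](=O)[O-])cc(C(F)(F)F)cc12`, is to be measured in this assay and differs from compound 2 by phenyl in place of cyclohexyl on a nitrogen on an aromatic ring. Going by the values given here, the only step that bears on it is an at least 11-fold lower number from compound 1 to compound 2 (1.07 log units; beyond the scatter), in which an aromatic substituent on that nitrogen was replaced by cyclohexyl. Compound 3 reverses that type of change, though not with the same group, so a step toward higher numbers in this assay is expected, a 4.6-fold higher number from compound 2 to compound 3 (0.67 log units; beyond the scatter). For compound 3 the estimate in this assay is 25 ug/mL, ranging from 6 ug/mL to 64 ug/mL.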

Compound 3, half-maximal inhibitory concentration: 37.9 ug/mL
Beside the measured number, compound 3's estimate is 1.5-fold (0.18 log units) below it, within the range that was stated.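

In this assay, phenyl in place of cyclohexyl on a nitrogen on an aromatic ring gives a 7.0-fold higher number from compound 2 to compound 3 (0.85 log units; beyond the scatter), so exchanging a non-aromatic ring of carbon for an aromatic one moves the number, although both groups have 6 heavy atoms. Compound 2 now stands apart from a measured neighbour and not only from a limit, while an at least 1.6-fold lower number from compound 1 to compound 3 (0.22 log units; that floor lies within the scatter) does not set those two compounds apart. Compound 1 remains a limit of the assay and not a number: the limit of > 64 ug/mL in this assay, at which 1 of the 3 values shown sits.

On these data alone, it remains open whether the lower number goes with non-aromatic rings generally or with cyclohexyl alone, which cyclopentyl or an open chain such as n-butyl would address. Also open, as far as these compounds go, is how an unsubstituted benzyl, or a phenyl carrying fluorine, would sit.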